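Working notes: from compound 3 to compound 4

The source may report more compounds than this note shows. Statements on the series, on what has been measured and on what is new or still open speak of the compounds shown alone.

Measured in a functional assay on HL-60 cells (Homo sapiens) for antiproliferative activity, read by MTT assay, with a stated time of 72 h; on this read-out higher numbers stand for weaker inhibition and lower numbers for stronger inhibition:
- compound 1 `C=C(Br)C(=O)Nc1ccc2c(c1)/C(=C\c1sccc1C)C(=O)N2`: 39 nM
- compound 2 `C=C(Br)C(=O)Nc1ccc2c(c1)/C(=C/c1ccc[nH]1)C(=O)N2`: 140 nM
- compound 3 `C=C(Br)C(=O)Nc1ccc2c(c1)/C(=C/c1ccsc1)C(=O)N2`: 350 nM

Of these three, compound 3 has the highest number, 350 nM. Compound 4 `C=C(Br)C(=O)Nc1ccc2c(c1)/C(=C/c1sccc1C)C(=O)N2` has 3-methylthiophen-2-yl in place of thiophen-3-yl on a double-bonded chain carbon bound to a double-bonded ring carbon.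

Within the data shown here, the only measured step at this place is modest: a 2.5-fold higher number from compound 2 to compound 3 (0.40 log units; beyond the scatter). Among the measured compounds shown here, compound 1 also carries 3-methylthiophen-2-yl and gives 39 nM, but no measured step links it to compound 4, so it is only a loose guide. A moderate move to a lower number is therefore expected in this assay. The expected change is a 2.9-fold lower number from compound 3 to compound 4 (0.46 log units; beyond the scatter). Compound 4 is estimated at 120 nM, with an expected range of 35 nM to 400 nM.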

Compound 4, half-maximal inhibitory concentration: 13 nM
The estimate for compound 4 lay 9.2-fold (0.97 log units) above the measured number, and the stated range ends above it.
By their numbers in this assay, from the lowest: compound 4; then compound 1; then compound 2; then compound 3.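

In this assay, 3-methylthiophen-2-yl in place of thiophen-3-yl gives a 27-fold lower number from compound 3 to compound 4 (1.43 log units; beyond the scatter), a large step where the earlier step at this place was modest. In place of 1H-pyrrol-2-yl, the same group gives an 11-fold lower number from compound 2 to compound 4 (1.03 log units; beyond the scatter). Configuration also matters at this double bond, with a 3.0-fold lower number from compound 1 to compound 4 (0.48 log units; beyond the scatter), and this step isolates it from any change of group: the fact that compounds 1 and 4 differ only in the configuration as drawn

The change from thiophen-3-yl to 3-methylthiophen-2-yl alters the methyl and the ring attachment together, and the compounds shown cannot separate the two. On these data alone, how an amine, a carboxylic acid or a longer chain in place of the methyl would behave at this place remains open.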